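The compounds below may be only part of what the source reports. "The series", "measured", "known", "first", "only" and "open" are said of these compounds alone.

Two amides built on a shared core have been measured in a functional assay on A375P cells (Homo sapiens) for antiproliferative activity, read by MTT assay, with a stated time of 48 h; on this read-out lower numbers stand for stronger inhibition and higher numbers for weaker inhibition. Compound 1 `COc1ccc(C(=O)Nc2cccc(-c3ccnc4c(N)cccc34)c2)cc1OC` carries a 3,4-dimethoxyphenyl group on its carbonyl carbon, and in this assay compound 1 gives 9500 nM. Compound 2 `Cc1ccc(C(=O)Nc2cccc(-c3ccnc4c(N)cccc34)c2)cc1C` carries a 3,4-dimethylphenyl group in that place instead. For compound 2 the read-out is a limit of the assay, > 20000 nM, so for compound 2 only a limit and no number is known. On these data alone, the step of an at least 2.1-fold higher number from compound 1 to compound 2 (0.32 log units; beyond the scatter) therefore describes a weakening that lies beyond the usual scatter, although its exact size stays open because the limit of > 20000 nM in this assay, at which 1 of the 2 values shown sits, marks where compound 2 sits.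

Compound 3 `Cc1cc(C(=O)Nc2cccc(-c3ccnc4c(N)cccc34)c2)ccc1Br` differs from compound 2 at one point: bromo in place of methyl on an aromatic carbon. For the measured compounds named here, no measured step covers an exchange of methyl for bromo, so the only guide is where compound 2 itself stands. Compound 3 is expected to remain in the same weak region, with an estimated 20000 nM and a likely range from 8000 nM to 50000 nM. The estimated step is a number no higher from compound 2 to compound 3 (the limit leaves the size open), with a real chance that this assay again reports only a limit.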

Compound 3, half-maximal inhibitory concentration: 9900 nM
Compound 3: middle estimate off by 2.0-fold (0.31 log units), on the high side; the range from low to high includes it.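

At this ring carbon, ortho to a methyl group and para to a large group, bromo in place of methyl turns a bare limit into a measured number in this assay, with an at least 2.0-fold lower number from compound 2 to compound 3 (0.30 log units; that floor lies within the scatter), so the exchange cannot be called a clear gain on its own. The comparison with compound 1 adds what the first pair could not show, a second measured acid part on the same amide, with a 1.0-fold higher number from compound 1 to compound 3 (0.02 log units; within the scatter), so the 4-bromo-3-methylphenyl group and the 3,4-dimethoxyphenyl group sit level in this read-out. On these data alone, the true size of the step to compound 3 stays open, because compound 2 is known only through a limit of the assay: the limit of > 20000 nM in this assay, at which 1 of the 3 values shown sits.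

As far as these compounds go, what chloro, an amine or a carboxylic acid would do at this same ring carbon remains open, so it cannot yet be said whether bromo is special here or whether methyl is the exception. Also open, from the compounds shown here alone, is how bromo would behave in place of one methoxy group of compound 1, where the partner group on the ring differs.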